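Benzylamine series: hydroxy for chloro on compound 1

The source may report more compounds than this note shows. Statements on the series, on what has been measured and on what is new or still open speak of the compounds shown alone.

Among the compounds with values here, compound 1 `COc1cc(Oc2cccc(Nc3ccccc3)c2)cc(OC)c1CNCc1ccc(Cl)cc1` is the only member of the set with a number in a functional assay on HCT-116 cells (Homo sapiens) for inhibition, read by MTT assay, with a stated time of 72 h (a higher number here means a weaker inhibitor, a lower number a stronger inhibitor), where compound 1 gives 3310 nM. Compound 2 `COc1cc(Oc2cccc(Nc3ccccc3)c2)cc(OC)c1CNC1CC1` reaches only the limit of the measurement, > 20000 nM. Compound 3 `COc1cc(Oc2cccc(Nc3ccccc3)c2)cc(OC)c1CNC(C)C` likewise sits at the limit, > 20000 nM. The measured steps run an at least 6.0-fold higher number from compound 1 to compound 2 (0.78 log units; beyond the scatter) and an at least 6.0-fold higher number from compound 1 to compound 3 (0.78 log units; beyond the scatter); both remove the whole 4-chlorobenzyl group, so they show that this group carries the activity but say nothing about its substituent. Compound 4 `COc1cc(Oc2cccc(Nc3ccccc3)c2)cc(OC)c1CNCc1ccc(O)cc1` differs from compound 1 only by hydroxy in place of chloro on an aromatic carbon. Within the data shown here, no measured step covers this change; the benzyl is kept, so the loss seen for compounds 2 and 3 is not expected, but a mild weakening is possible. For compound 4 the expected step is a 1.7-fold higher number from compound 1 to compound 4 (0.22 log units; within the scatter), and its estimate is 5500 nM with a range of 1800 nM to 18000 nM.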

Compound 4, half-maximal inhibitory concentration: 3360 nM
Compound 4: the middle estimate sits 1.6-fold (0.21 log units) above what was measured; low and high end bracket the measured number.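

In this assay, hydroxy can replace chloro on the benzyl ring with no readable change: a 1.0-fold higher number from compound 1 to compound 4 (0.01 log units; within the scatter). The activity of the benzyl series is therefore not tied to chloro, and the 4-hydroxybenzyl group also separates from the small amine substituents, with an at least 5.9-fold lower number from compound 3 to compound 4 (0.77 log units; beyond the scatter) and an at least 5.9-fold lower number from compound 2 to compound 4 (0.77 log units; beyond the scatter). Both of these steps are bounded rather than exact, as compounds 2 and 3 sit at a limit: the limit of > 20000 nM in this assay, at which 2 of the 4 values shown sit.

As far as these compounds go, whether methoxy, an amine or a carboxylic acid would be tolerated at this place stays open. The compounds shown also cannot tell whether the unsubstituted benzyl group would match compound 1.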